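Adding a Sugar Ring to the Alcohol of Compound 1

The compounds below may be only part of what the source reports. "The series", "measured", "known", "first", "only" and "open" are said of these compounds alone.

a functional assay on SK-MEL-2 cells (Homo sapiens) for cytotoxicity, read by sulforhodamine B assay (on this read-out higher numbers stand for an effect only at larger amounts of compound and lower numbers for an effect already at smaller amounts), is the measure throughout. Compound 1 `C=C[C@](C)(O)CC[C@H]1C(C)=CC[C@H]2C(C)(C)CCC[C@]12C` gives 4.4 ug/mL in this assay, the highest of the two plain numbers shown. Compound 2 `C=C[C@@](C)(CC[C@H]1C(C)=CC[C@H]2C(C)(C)CCC[C@]12C)O[C@@H]1O[C@H](C)[C@H](OC(C)=O)[C@H](O)[C@H]1O` gives 3.4 ug/mL in this assay, a value within the usual scatter of that of compound 1. Compound 3 `C=C[C@@](C)(CC[C@@H]1[C@@]2(C)CCCC(C)(C)[C@@H]2CC[C@@]1(C)O)O[C@H]1O[C@H](C)[C@H](O)[C@@H](O)[C@@H]1O` reaches only a limit in this assay, > 5 ug/mL, so no number is known for it; this is the limit of > 5 ug/mL in this assay, at which 1 of the 3 values shown sits. Compound 4 `C=C[C@@](C)(CC[C@H]1C(C)=CC[C@H]2C(C)(C)CCC[C@]12C)O[C@@H]1O[C@@H](C)[C@@H](O)[C@H](O)[C@H]1O` is not yet measured. It differs from compound 1 by a group of 10 heavy atoms (6 carbon, 4 oxygen; one six-membered non-aromatic ring with 1 hetero atom) in place of a hydrogen atom, on an oxygen on a saturated carbon. Going by the values given here, no measured pair isolates this change, so the step of a 1.0-fold higher number from compound 1 to compound 4 (0.01 log units; within the scatter) is expected to be small, with no direction beyond the scatter. Compound 4 is therefore estimated at 4.5 ug/mL, with a range from 2.5 ug/mL to 8 ug/mL in this assay.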

Compound 4, concentration for half-maximal effect: 4.2 ug/mL
Compound 4: middle estimate off by 1.1-fold (0.03 log units), on the high side, within the range that was stated.
By their numbers in this assay, from the lowest: compounds 2, 4 and 1 (each within the scatter of the next). At a limit, above all of these: compound 3.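

Going by these compounds alone, this is the first pair that differs in one place only. Putting a six-membered non-aromatic ring of 10 heavy atoms in place of the hydrogen atom on this oxygen gives a 1.0-fold lower number from compound 1 to compound 4 (0.02 log units; within the scatter) and so leaves the number where it was. Even this large a group on the oxygen on a saturated carbon therefore does not shift the cytotoxicity read-out beyond the scatter.

As far as these compounds go, whether a small acetyl group or an amine on this oxygen would behave the same way stays open. Nothing shown here gives a cause for so small a step.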